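Removing a trifluoromethyl from an amidine aryl ring

The source may report more compounds than this note shows. Statements on the series, on what has been measured and on what is new or still open speak of the compounds shown alone.

All three measured compounds were tested in a functional assay on MDA-MB-231 cells (Homo sapiens) for cytotoxicity, read by MTT assay, with a stated time of 72 h; a lower number here means a stronger inhibitor, a higher number a weaker inhibitor:
- compound 1 `COc1cc(Nc2nc(C(=N)Nc3ccccc3)cc3c(-c4ccccc4)n[nH]c23)cc(OC)c1OC` gives 4500 nM
- compound 2 `COc1ccc(Cn2nc(-c3ccccc3)c3cc(C(=N)Nc4ccc(N5CCN(C)CC5)cc4)nc(Nc4cc(OC)c(OC)c(OC)c4)c32)cc1` gives 890 nM
- compound 3 `COc1ccc(Cn2nc(-c3ccccc3)c3cc(C(=N)Nc4cccc(C(F)(F)F)c4)nc(Nc4cc(OC)c(OC)c(OC)c4)c32)cc1` gives > 50000 nM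

Compound 1 and compound 2 both give numbers in this assay. Compound 3 does not: its value of > 50000 nM is a limit of the assay, not a measured number, so it is only known that compound 3 sits at the limit of > 50000 nM in this assay, at which 1 of the 3 values shown sits. Compound 3 therefore stands at the weak end of what has been seen so far, without a number of its own.

Compound 4 `COc1ccc(Cn2nc(-c3ccccc3)c3cc(C(=N)Nc4ccccc4)nc(Nc4cc(OC)c(OC)c(OC)c4)c32)cc1` has not yet been measured in this assay. It differs from compound 3 in one place: hydrogen in place of trifluoromethyl on an aromatic carbon. Among the compounds with values here, no measured pair in this set isolates this change, so its size cannot be read from the data. Since compound 3 is only a limit, any real number for compound 4 would count as a move toward stronger inhibition, and the expected step from compound 3 to compound 4 is an at least 10-fold lower number from compound 3 to compound 4 (1.00 log units; beyond the scatter). Compound 4 is expected to give about 5000 nM, with a range from 1000 nM to 30000 nM.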

Compound 4, half-maximal inhibitory concentration: 42100 nM
Beside the measured number, compound 4's estimate is 8.4-fold (0.93 log units) below it; measured number above the stated range.
By their numbers in this assay, from the lowest: compound 2; then compound 1; then compound 4. At a limit, above all of these: compound 3.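

Removing the trifluoromethyl gives compound 4 a measurable value in this assay, yet the firm gain at this position is small: the data show an at least 1.1-fold lower number from compound 3 to compound 4 (0.07 log units; that floor lies within the scatter). Compound 3 remains a limit of the assay, not a measured number: the limit of > 50000 nM in this assay, at which 1 of the 4 values shown sits.

The plain phenyl compound also gives a new reference point for two other single changes: replacing 4-methylpiperazin-1-yl with hydrogen on the aromatic ring gives a 47-fold higher number from compound 2 to compound 4 (1.67 log units; beyond the scatter), and placing 4-methoxybenzyl on the aromatic nitrogen in place of hydrogen, read in the listed direction, gives a 9.4-fold higher number from compound 1 to compound 4 (0.97 log units; beyond the scatter). At this point, then, the trifluoromethyl step cannot be sized exactly, whereas the other two steps are clearly beyond the usual scatter.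

These compounds leave open whether the lower number of compound 2 is specific to 4-methylpiperazin-1-yl, or whether a simple amine or a morpholine on the same ring would give a similar result. They also leave open how a small methyl group on the aromatic nitrogen would compare with hydrogen and 4-methoxybenzyl.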